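The compounds below may be only part of what the source reports. "The series", "measured", "known", "first", "only" and "open" are said of these compounds alone.

Three compounds of the series carry numbers in a functional assay on CHO cells for agonist activity at Free fatty acid receptor 1 (Homo sapiens), read by a luciferase reporter; on this read-out higher numbers stand for larger maximal responses and lower numbers for smaller maximal responses. Compound 1 `O=C(O)/C=C/c1ccc(NCc2cccc(Oc3ccccc3)c2)cc1` gives 76%. Compound 2 `Cc1nc(-c2ccc(C(F)(F)F)cc2)sc1CNc1ccc(C(C)CC(=O)O)cc1` gives 109%, and compound 3 `Cc1nc(-c2ccc(C(F)(F)F)cc2)sc1CNc1ccc(CCC(=O)NC(C)C)cc1` gives 84%. Compound 1 stands lowest of the three numbers: its gap to compound 3 lies within the scatter, while compound 2 lies beyond the scatter above it. Among the compounds with values here, the one measured step that alters a single place is a number 25 percentage points lower from compound 2 to compound 3 (beyond the scatter), in which the carboxylic acid is exchanged for an amide. Compound 4 `CN(C)C(=O)CCc1ccc(NCc2cccc(Oc3ccccc3)c2)cc1` has not been measured; it differs from compound 1 by 2-(dimethylcarbamoyl)ethyl in place of 2-carboxyethenyl on an aromatic carbon. Here too the carboxylic acid gives way to an amide, a dimethylcarbamoyl group, and one of the double bonds outside aromatic rings is lost as well. Within the data shown here, the step from compound 2 to compound 3 is the only guide and points downward by a modest amount, so a downward step of similar size is expected, a number 21 percentage points lower from compound 1 to compound 4 (beyond the scatter). Compound 4 is therefore estimated at 55%, with a range from 35% to 75%.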

Compound 4, largest response reached (reported as percent of maximum), in percent of the reference or control that the assay uses: 50%
Beside the measured number, compound 4's estimate is 5 percentage points above it; low and high end bracket the measured number.
By their numbers in this assay, from the lowest: compound 4; then compounds 1 and 3 (each within the scatter of the next); then compound 2.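

In this assay, 2-(dimethylcarbamoyl)ethyl in place of 2-carboxyethenyl at this position on the core of compound 1 gives a number 26 percentage points lower from compound 1 to compound 4 (beyond the scatter). A second core therefore shows a fall beyond the scatter when the carboxylic acid gives way to an amide, in the same direction as a number 25 percentage points lower from compound 2 to compound 3 (beyond the scatter), and neither of these two pairs goes against it. This change also removes a double bond outside aromatic rings and leaves the entering group with 0 hydrogen-bond donors, and no available data explain the step.

A 2-carboxyethyl group on the core of compound 1 would separate the loss of the double bond from the loss of the carboxylic acid. As far as these compounds go, whether a 2-(isopropylcarbamoyl)ethyl group or a tetrazole at this position behaves likewise remains open.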